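The source may hold more compounds than are shown below. What is called first, only, known or untested is meant among the compounds shown, and "the series" means these compounds.

Three compounds share one core and differ only in the group at the far end of the long saturated chain. Compound 1 `CCCCCCCCCCCC[C@@H](O)[C@H]1CC[C@H]([C@H](O)CCCCCCCCCCNC(=O)c2ccnn2C)O1` carries an amide with a free amide hydrogen; in a functional assay on OVCAR-3 cells (Homo sapiens) for inhibition, read by sulforhodamine B assay, with a stated time of 48 h (on this read-out lower numbers stand for stronger inhibition of growth and higher numbers for weaker inhibition of growth), compound 1 gives 77600 nM. Compound 2 `CCCCCCCCCCCC[C@@H](O)[C@H]1CC[C@H]([C@H](O)CCCCCCCCCCN(C)C(=O)c2ccnn2C)O1` carries a methyl on that amide nitrogen, and compound 2 gives 10000 nM. Compound 3 `CCCCCCCCCCCC[C@@H](O)[C@H]1CC[C@H]([C@H](O)CCCCCCCCCCNCc2ccnn2C)O1` carries an amine in place of the amide, and compound 3 gives 1510 nM, the lowest of the three numbers. The unmeasured compound 4 `CCCCCCCCCCCC[C@@H](O)[C@H]1CC[C@H]([C@H](O)CCCCCCCCCCOC(=O)c2ccnn2C)O1` differs from compound 3 by ((1-methyl-1H-pyrazol-5-yl)carbonyl)oxy in place of ((1-methyl-1H-pyrazol-5-yl)methyl)amino on a saturated chain carbon, ten or more bonds along the chain from an oxygen on a saturated carbon and a saturated ring carbon. This change brings back a carbonyl and removes the hydrogen-bond donor, which makes the two steps from the amides to the amine the relevant ones: a 51-fold lower number from compound 1 to compound 3 (1.71 log units; beyond the scatter) and a 6.6-fold lower number from compound 2 to compound 3 (0.82 log units; beyond the scatter), both pointing away from the direction now taken. A move back toward the amide numbers is expected, of a size between those two steps. Compound 4 is expected to show a 13-fold higher number from compound 3 to compound 4 (1.12 log units; beyond the scatter) in this assay. The estimate for compound 4 is 20000 nM, with a range from 5000 nM to 80000 nM.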

Compound 4, concentration for 50% growth inhibition: 100000 nM
Compound 4: the middle estimate sits 5.0-fold (0.70 log units) below what was measured; measured number outside the range, above it.
By their numbers in this assay, from the lowest: compound 3; then compound 2; then compounds 1 and 4 (each within the scatter of the next).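

In this assay, replacing the amide nitrogen with an oxygen makes no readable difference: a 1.3-fold higher number from compound 1 to compound 4 (0.11 log units; within the scatter) lies within the usual scatter. Compound 4 has no hydrogen-bond donor at this chain end, yet it does not follow compound 2, which also lacks the amide hydrogen, as a 10-fold higher number from compound 2 to compound 4 (1.00 log units; beyond the scatter) shows; losing that hydrogen therefore does not by itself bring the number down. The amine stands well apart from the ester, with a 66-fold higher number from compound 3 to compound 4 (1.82 log units; beyond the scatter), so of these four end groups only the amine gives a number far below those of compound 1 and compound 4.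

Nothing in the available data explains these differences. Still open, going by these compounds, is how the number would respond to a methyl on the amine nitrogen of compound 3, or to a plain ether linking the chain to the pyrazole.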